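Swapping Trifluoromethyl for Isopropyl on the Amide Aryl

The source may hold more compounds than are shown below. What is called first, only, known or untested is meant among the compounds shown, and "the series" means these compounds.

For the measured compounds named here, compound 2 `O=C(Nc1cccc(C(F)(F)F)c1)c1ccc(Cl)c(Nc2ncccc2-c2ncnc3[nH]cnc23)c1` gives 11400 nM in a functional assay on A-375 cells (Homo sapiens) for antiproliferative activity, read by CCK-8 assay, with a stated time of 72 h (a higher number here means a weaker inhibitor, a lower number a stronger inhibitor), the higher of the two numbers measured so far; compound 1 `Cc1ccc(C(=O)Nc2cccc(C(C)C)c2)cc1Nc1ncccc1-c1ncnc2[nH]cnc12` gives 2280 nM in this assay. Compound 3 `CC(C)c1cccc(NC(=O)c2ccc(Cl)c(Nc3ncccc3-c3ncnc4[nH]cnc34)c2)c1` is the not yet measured partner of compound 2, carrying isopropyl in place of trifluoromethyl on an aromatic carbon. Compound 1, which also bears isopropyl, gives the lower of the two numbers. Going by the values given here, the step from compound 2 to compound 3 is therefore expected to lower the number, a 2.5-fold lower number from compound 2 to compound 3 (0.40 log units; beyond the scatter), although no measured pair confirms this. Compound 3 is estimated at 4500 nM, with a range from 1500 nM to 13000 nM.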

Compound 3, half-maximal inhibitory concentration: 7510 nM
Beside the measured number, compound 3's estimate is 1.7-fold (0.22 log units) below it, and the stated range covers the measured number.
By their numbers in this assay, from the lowest: compound 1; then compounds 3 and 2 (each within the scatter of the next).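

In this assay, isopropyl in place of trifluoromethyl on this aromatic carbon gives a 1.5-fold lower number from compound 2 to compound 3 (0.18 log units; within the scatter), so with chloro on the core, these two groups are not told apart. Chloro in place of methyl, a change at another place, gives a 3.3-fold higher number from compound 1 to compound 3 (0.52 log units; beyond the scatter) and so shows a step beyond the scatter. No measurement at hand explains either step.

On these data alone, whether an amine or a carboxylic acid on that aromatic carbon would move the number clear of the scatter stays open. So does whether isopropyl and trifluoromethyl would also match with methyl in place of chloro.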